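A few compounds are considered here, and "the series" means these few. Any claim that something is new, unique, unknown or untested is made for them only; others in the source may bear on it.

Compound 2 `COc1cc(-c2cc(/C=C/C(=O)c3ccc(N)cc3)[nH]n2)cc(OC)c1OC` is the starting point here. Within the data shown here, in a functional assay on OVCAR-3 cells (Homo sapiens) for cytotoxicity, read by sulforhodamine B assay, with a stated time of 48 h, tested at 10 uM (on this read-out lower numbers stand for a stronger effect and higher numbers for a weaker effect at the one concentration tested), compound 2 gives -71%, the lowest of the three numbers known. Compound 1 `COc1ccc(-c2cc(/C=C/C(=O)c3ccc(N)cc3)[nH]n2)cc1` gives -70%, which sits within the scatter of compound 2. Among the measured compounds shown here, compound 3 `COc1cc(-c2cc(/C=C/C(=O)c3ccc(Cl)c(Cl)c3)[nH]n2)cc(OC)c1OC` gives 40%, and the step of a number 111 percentage points higher from compound 2 to compound 3 (beyond the scatter) is the only change larger than the scatter seen so far. Compound 4 `COc1ccc(-c2cc(/C=C/C(=O)c3ccc(N)cc3)[nH]n2)cc1OC` differs from compound 2 by hydrogen in place of methoxy on an aromatic carbon. For the measured compounds named here, no measured step alters a methoxy group, so none bears directly on this change; compound 1, with one methoxy fewer still, shows a value within the scatter of compound 2, which suggests a small step. Compound 4 is therefore expected to give about -70%, between -85% and -50%, a step of a number 1 percentage points higher from compound 2 to compound 4 (within the scatter) expected to stay within the scatter.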

Compound 4, a percentage reported as activity, at one concentration (the size of the read-out at that concentration, not a potency): -56%
Compound 4: middle estimate off by 14 percentage points, on the low side, and the stated range covers the measured number.
By their numbers in this assay, from the lowest: compounds 2 and 1 (each within the scatter of the next); then compound 4; then compound 3.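

In this assay this position on the ring is not neutral: hydrogen in place of methoxy gives a number 15 percentage points higher from compound 2 to compound 4 (beyond the scatter) and methoxy in place of hydrogen gives a number 14 percentage points higher from compound 1 to compound 4 (beyond the scatter). The number therefore does not simply follow the count of methoxy groups, since compound 4 lies above both of its neighbours, which carry more and fewer of them. Nothing available explains this reversal. Still open, as far as these compounds go, is whether a hydroxyl, a fluorine or an ethoxy group at this position would sit nearer compound 2 or compound 4. From the compounds shown here alone, it is also open whether the same step would appear with the 3,4-dichlorophenyl group of compound 3 on the carbonyl carbon.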